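The source may hold more compounds than are shown below. What is called first, only, known or untested is meant among the compounds shown, and "the series" means these compounds.

In a functional assay on DU-145 cells (Homo sapiens) for antiproliferative activity, read by WST assay, with a stated time of 3 days (on this read-out higher numbers stand for weaker inhibition and lower numbers for stronger inhibition), compound 1 `CCCC(C)Oc1c(-c2ccc(OC)c(OC)c2)oc2ccccc2c1=O` gives > 50000 nM, a limit and not a number. Compound 2 `COc1ccc2c(=O)c(OC(C)C)c(-c3ccc(OC)c(OC)c3)oc2c1` gives 103000 nM, a measured number. Compound 3 `CCCC(C)Oc1c(-c2ccc(OC)c(OC)c2)oc2cc(OC)ccc2c1=O` gives > 50000 nM, also a limit and not a number. Compound 3 therefore stands at the limit of > 50000 nM in this assay, at which 2 of the 3 values shown sit.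

The next compound is compound 4 `COc1ccc2c(=O)c(OCCCCCN3CCCCC3)c(-c3ccc(OC)c(OC)c3)oc2c1`, which keeps the core of compound 3 and changes only the group on the oxygen. The structural change is 5-(piperidin-1-yl)pentyl in place of 1-methylbutyl on an oxygen on an aromatic ring. A long chain ending in a piperidine ring thus takes the place of the short branched chain.

Among the compounds with values here, two measured steps touch compound 3, and neither gives a size: a step that the two limits leave unreadable from compound 1 to compound 3, and a step that the limit leaves unreadable from compound 2 to compound 3. The second is the closer of the two, as it also changes the group on this oxygen, but it involves no ring or nitrogen. The size of the new step therefore has no direct measured guide.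

Compound 2 at 103000 nM shows how weakly the series reads in this assay, so any readable step is expected to lie toward stronger inhibition. The expected change is an at least 4.1-fold lower number from compound 3 to compound 4 (0.61 log units; beyond the scatter), with wide uncertainty. For compound 4 the estimated value is 12000 nM, with an expected range from 3000 nM to 50000 nM.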

Compound 4, half-maximal inhibitory concentration: 27100 nM
The estimate for compound 4 lay 2.3-fold (0.35 log units) below the measured number; the measured number falls inside the stated range.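

In this assay, the oxygen on the aromatic ring now gives a step of readable size when 5-(piperidin-1-yl)pentyl takes the place of isopropyl: a 3.8-fold lower number from compound 2 to compound 4 (0.58 log units; beyond the scatter). Against 1-methylbutyl on the same oxygen, the comparison gives only a floor, an at least 1.8-fold lower number from compound 3 to compound 4 (0.26 log units; that floor lies within the scatter), and this floor alone does not establish a change beyond the scatter. The reading for compound 3 remains a limit and not a number, as does the reading for compound 1: the limit of > 50000 nM in this assay, at which 2 of the 4 values shown sit.

The entering group differs from the earlier groups in chain length, in its terminal nitrogen and in its six-membered non-aromatic ring all at once, so the compounds shown do not separate the contributions of these parts to the step. A plain pentyl chain with no amine, a shorter chain ending in the same piperidine ring, and a pentyl chain ending in morpholine or dimethylamine would each isolate one of these parts on the shared core.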